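Adding a Methyl Next to the Core: What to Expect

The source may report more compounds than this note shows. Statements on the series, on what has been measured and on what is new or still open speak of the compounds shown alone.

In a functional assay on A549 cells (Homo sapiens) for antiproliferative activity, read by MTT assay, with a stated time of 48 h (a higher number here means a weaker inhibitor, a lower number a stronger inhibitor), compound 1, `COc1ccc(-c2cc3c(cn2)[nH]c(=O)n3-c2cc(OC)c(OC)c(OC)c2)cc1F`, gives 2020 nM. Compound 2, `CCOc1ccc(-c2cc3c(cn2)[nH]c(=O)n3-c2cc(OC)c(OC)c(OC)c2)cc1F`, carries methyl in place of hydrogen on a saturated chain carbon bound to an oxygen on an aromatic ring; in this assay compound 2 gives 2540 nM, so the step of a 1.3-fold higher number from compound 1 to compound 2 (0.10 log units; within the scatter) is small. Compound 3, `CCn1c(=O)n(-c2cc(OC)c(OC)c(OC)c2)c2cc(-c3ccc(OC)c(O)c3)ncc21`, has a core whose difference from compound 1 is not broken down here. In this assay compound 3 reaches only a limit, > 20000 nM, which is the limit of > 20000 nM in this assay, at which 1 of the 3 values shown sits.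

Compound 4, `COc1ccc(-c2cc3c(cn2)n(C(C)C)c(=O)n3-c2cc(OC)c(OC)c(OC)c2)cc1O`, differs by methyl in place of hydrogen on a saturated chain carbon bound to an aromatic nitrogen and a saturated chain carbon. This is the same kind of change as from compound 1 to compound 2, but the place differs: there the carbon is bound to an oxygen on an aromatic ring, here to an aromatic nitrogen and a saturated chain carbon. Because the measured step of a 1.3-fold higher number from compound 1 to compound 2 (0.10 log units; within the scatter) was small, and compound 3 sits at a limit, little movement is expected. The expected step is a step that the limit leaves unreadable from compound 3 to compound 4. Compound 4 is estimated at 25000 nM, likely between 8000 nM and 60000 nM, and most probably again only a limit.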

Compound 4, half-maximal inhibitory concentration: 7210 nM
Estimate against measurement, compound 4: 3.5-fold (0.54 log units) above; measured number below the stated range.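

In this assay, changing ethyl to isopropyl, a methyl in place of hydrogen on a saturated chain carbon bound to an aromatic nitrogen and a saturated chain carbon, gives an at least 2.7-fold lower number from compound 3 to compound 4 (0.44 log units; beyond the scatter). Set beside the earlier methyl step, this shows that the same kind of change need not have the same result on another core: the same change on two cores in this assay, a 1.3-fold higher number (0.10 log units; within the scatter) from compound 1 to compound 2 and an at least 2.7-fold lower number (0.44 log units; beyond the scatter) from compound 3 to compound 4, at least 3.4-fold (0.54 log units) apart, beyond the scatter of two such steps The two steps differ in place as well as in core, so they cannot show which of these matters, and the second step has only a minimum size, as compound 3 stands at a limit: the limit of > 20000 nM in this assay, at which 1 of the 4 values shown sits.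

Two steps are too few to give a rule for this series. From the compounds shown here alone, whether a longer chain or a chain ending in an amine at this place would lower the number further stays open.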